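Chloroacetamide to dithiocarbamate lactone on the chalcone amide

This account rests on a few compounds, and the source may have more. Where it says the series, first, only, none or still open, it means among the compounds named here.

Two compounds of this series carry a measured number. Compound 1 `O=C(CCl)Nc1ccc(C(=O)/C=C/c2ccc([N+](=O)[O-])cc2)cc1` gives 3670 nM in a functional assay on EC9706 cells (Homo sapiens) for cytotoxicity, read by MTT assay, with a stated time of 72 h (on this read-out higher numbers stand for weaker inhibition and lower numbers for stronger inhibition), the lowest of the two numbers. Compound 2 `Cc1ccc(/C=C/C(=O)c2ccc(NC(=O)CCl)cc2)cc1` gives 7150 nM in the same assay. Among the compounds with values here, the single step that the measured pair offers, a 1.9-fold higher number from compound 1 to compound 2 (0.29 log units; within the scatter), concerns an exchange on the aromatic ring at the far end of the shared core and is within the scatter.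

Compound 3 `O=C(CSC(=S)N[C@H]1CCOC1=O)Nc1ccc(C(=O)/C=C/c2ccc([N+](=O)[O-])cc2)cc1` differs from compound 1 elsewhere: a group of 10 heavy atoms (5 carbon, 1 nitrogen, 2 oxygen, 2 sulfur; one five-membered non-aromatic ring with 1 hetero atom) in place of one chlorine atom, on a saturated chain carbon bound to a carbonyl carbon. Within the data shown here, no measured pair changes the chloroacetamide end of the shared core, so the step from compound 1 to compound 2 does not bear on this exchange and gives no direction for it. Among the measured compounds shown here, with the one measured step lying within the scatter, and no step at the changed position, the expected size of the step is taken as none beyond the scatter, with a wide spread to either side. The estimated step of a 1.4-fold higher number from compound 1 to compound 3 (0.13 log units; within the scatter) is therefore centred near the value of compound 1. Compound 3 is estimated at 5000 nM in this assay, expected to fall between 1000 nM and 25000 nM.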

Compound 3, half-maximal inhibitory concentration: > 128000 nM
Compound 3 ended at the assay's limit; the forecaster's own chance of this, stated with the estimate: 10%; middle value at least 25-fold (1.40 log units) away from the limit.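

Notes on the chloroacetamide end: this position matters strongly in this assay, which the aromatic exchange could not show, since it gave only a 1.9-fold higher number from compound 1 to compound 2 (0.29 log units; within the scatter). Placing the group of 10 heavy atoms on the saturated chain carbon bound to a carbonyl carbon, in place of one chlorine atom, gives an at least 34-fold higher number from compound 1 to compound 3 (1.54 log units; beyond the scatter), so at this position, in the nitro series, the chlorine atom cannot be replaced by this group with activity kept. For compound 3 the value is a limit of the assay and not a number, so the step sets only a lower bound on the change: the limit of > 128000 nM in this assay, at which 1 of the 3 values shown sits.

The exchange removes the chlorine atom and brings in the five-membered non-aromatic ring, its sulfur-bearing link and a defined stereocentre all at once, so the compounds shown do not tell which part of the change accounts for the step. From the compounds shown here alone, a simple amine or a bromine atom on the same carbon would help separate these parts, and it remains open whether the methyl compound, compound 2, responds to the same exchange as compound 1 does.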